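This account rests on a few compounds, and the source may have more. Where it says the series, first, only, none or still open, it means among the compounds named here.

In a functional assay on the whole organism for antagonist activity, with Mus musculus as the target (a lower number here means that less compound is needed, a higher number that more compound is needed for the effect), two closely related compounds have been measured so far. Compound 1 `CCC(=O)N(c1cccc(F)c1)C1CCCC1N(C)C` gives 0.6 mg/kg, and compound 2 `CCC(=O)N(c1cccc(Br)c1)C1CCCC1N(C)C` gives 0.1 mg/kg, the lower of the two numbers. The next compound, compound 3 `CCC(=O)N(c1ccc(Br)c(Br)c1)C1CCCC1N(C)C`, keeps all of compound 2 and gains a second halogen: bromo in place of hydrogen on an aromatic carbon. This is bromo in place of hydrogen on an aromatic carbon, ortho to a bromo group and para to a large group.

Within the data shown here, no measured step shows a change at this place, so the evidence is indirect. Among the measured compounds shown here, the only step available is a 6.0-fold lower number from compound 1 to compound 2 (0.78 log units; beyond the scatter), a modest change beyond the scatter, seen when bromo replaced fluoro on an aromatic carbon. In that single case, bromo came with the lower number, but one step cannot establish a trend. A small further drop in this assay is therefore expected, and it may well stay within the scatter. The estimated change is a 1.3-fold lower number from compound 2 to compound 3 (0.10 log units; within the scatter). For compound 3, the expected value is 0.08 mg/kg, with an estimated range from 0.02 mg/kg to 0.35 mg/kg.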

Compound 3, dose for half-maximal effect: 0.2 mg/kg
Estimate against measurement, compound 3: 2.5-fold (0.40 log units) below, and the stated range covers the measured number.
By their numbers in this assay, from the lowest: compounds 2 and 3 (each within the scatter of the next); then compound 1.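

In this assay, placing a bromo on an aromatic carbon, ortho to a bromo group and para to a large group, gives a 2.0-fold higher number from compound 2 to compound 3 (0.30 log units; within the scatter) and so leaves compound 2 and compound 3 indistinguishable in this test. Among these compounds, this is the first measured change at this position, and it shows that the whole organism still responds at a similar dose when a hydrogen here gives way to a bromo, the one heavy atom that this change adds. The result therefore gives no sign that this position must carry a hydrogen, nor any sign that a second bromo offers a measurable gain, and no accompanying measurement explains the outcome.

The compounds shown carry only a bromo at this position, so it remains open whether a fluoro, a methoxy group or an amine here would give a similar dose or a clearly different one. On these data alone, it is also open whether a bromo at this position would give a similar result without the bromo group already on the ring, or alongside a fluoro in its place.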